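The source may report more compounds than this note shows. Statements on the series, on what has been measured and on what is new or still open speak of the compounds shown alone.

Compound 1, `CSc1ccc(Cc2nn(C(C)(C)C)c(=O)c3ccccc23)cc1`: in a functional assay on aorta with Alpha-1D adrenergic receptor (Rattus norvegicus) as the target (a lower number here means that less compound is needed, a higher number that more compound is needed for the effect), compound 1 gives > 100000 nM, which is a limit of the assay and not a number.
Compound 2, `CCCCn1nc(Cc2ccc(SC)cc2)c2ccccc2c1=O`: in this assay compound 2 gives > 100000 nM, again a limit of the assay rather than a number.

Compound 2 therefore stands only at the limit of > 100000 nM in this assay, at which 2 of the 2 values shown sit. For the measured compounds named here, the one measured step, a step that the two limits leave unreadable from compound 1 to compound 2, cannot be sized, because both ends of it are limits. Compound 3, `C=CCn1nc(Cc2ccc(SC)cc2)c2ccccc2c1=O`, differs from compound 2 by vinyl in place of propyl on a saturated chain carbon bound to an aromatic nitrogen, a change on the same chain that the measured step altered. That step is the only one that bears on the chain on the aromatic nitrogen, and it gives no readable size or direction, so no shift beyond the scatter can be expected from it. With both shown values at the limit, compound 3 is expected to remain there as well, a step that the limit leaves unreadable from compound 2 to compound 3. Compound 3 is therefore estimated at 200000 nM, with a range from 50000 nM to 1000000 nM.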

Compound 3, half-maximal effective concentration: > 100000 nM
Compound 3 gave a limit, no number; the forecaster's own chance of this, stated with the estimate: 85%; the middle value lies beyond the limit too.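

The steps among compound 1, compound 2 and compound 3 cannot be read, as all three results are limits of the assay and not numbers: the limit of > 100000 nM in this assay, at which 3 of the 3 values shown sit.

The compounds shown leave open whether tert-butyl, butyl and allyl on the aromatic nitrogen differ at all in this assay, and by how much.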